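A few compounds are considered here, and "the series" means these few. Any claim that something is new, unique, unknown or untested is made for them only; others in the source may bear on it.

Working notes on the series, read in a functional assay on KYSE-450 cells (Homo sapiens) for inhibition, read by MTT assay, with a stated time of 48 h; a lower number here means a stronger inhibitor, a higher number a weaker inhibitor. Compound 1 (`C/C=C/C(=O)N(Cc1ccc(OC)c([N+](=O)[O-])c1)c1cc(OC)c(OC)c(OC)c1`) gives 510 nM, and compound 2 (`CCCCC(=O)N(Cc1ccc(OC)c(O)c1)c1cc(OC)c(OC)c(OC)c1`) gives 300 nM. Compound 3 (`COc1ccc(CNc2cc(OC)c(OC)c(OC)c2)cc1Cl`) gives 47800 nM, the highest number of the three and beyond the scatter from both others. Compound 4 (`COc1ccc(CNc2cc(OC)c(OC)c(OC)c2)cc1F`) is not yet measured. It differs from compound 3 by a single exchange, fluoro in place of chloro on an aromatic carbon, ortho to a methoxy group. Among the compounds with values here, no measured pair shows this exchange, so no change beyond the scatter is expected, leaving the number near that of compound 3 at 47800 nM. The expected 1.2-fold lower number from compound 3 to compound 4 (0.08 log units; within the scatter) is small. The estimated value for compound 4 is 40000 nM, with an expected range of 13000 nM to 100000 nM.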

Compound 4, half-maximal inhibitory concentration: 46200 nM
The estimate for compound 4 lay 1.2-fold (0.06 log units) below the measured number; the range from low to high includes it.
By their numbers in this assay, from the lowest: compounds 2 and 1 (each within the scatter of the next); then compounds 4 and 3 (each within the scatter of the next).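

In this assay, fluoro in place of chloro on an aromatic carbon, ortho to a methoxy group, gives a 1.0-fold lower number from compound 3 to compound 4 (0.01 log units; within the scatter) and so leaves the number unchanged. Within the data shown here, this is the first measured pair at this position, and it shows that the two halogens cannot be told apart here on this core. Nothing measured accounts for this result.

Still open, from the compounds shown here alone, is whether a nitrile or a methyl group at this position would also leave the number unchanged. Also open, going by these compounds, is whether the same exchange would read alike on the core of compound 1.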